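The compounds below may be only part of what the source reports. "The series", "measured", "known", "first", "only" and "open" are said of these compounds alone.

Measured compounds:
compound 1, `O=C1c2sccc2N(Cc2ccccc2)S(=O)(=O)N1Cc1ccccc1`; in an ADME assay on MT4 cells (Homo sapiens) for cytotoxicity, read by MTT assay, with a stated time of 4 days (a higher number here means that more compound is tolerated, a lower number that less compound is tolerated), compound 1 gives 37500 nM.
compound 2, `N#Cc1cccc(CN2c3ccsc3C(=O)N(Cc3ccccc3)S2(=O)=O)c1`; in this assay compound 2 gives > 305000 nM, which is a limit of the assay and not a number.

Compound 2 thus stands only as a limit on the numbers shown, at the limit of > 305000 nM in this assay, at which 1 of the 2 values shown sits. Among the compounds with values here, the single measured step, an at least 8.1-fold higher number from compound 1 to compound 2 (0.91 log units; beyond the scatter), is the only step, and it ends at that limit.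

Compound 3, `CN1c2ccsc2C(=O)N(Cc2ccccc2)S1(=O)=O`, is the unmeasured member. It differs from compound 2 by hydrogen in place of 3-cyanophenyl on a saturated chain carbon bound to a sulfonamide nitrogen in a ring. Within the data shown here, no measured step removes the whole 3-cyanobenzyl group, so the step into compound 3 has no direct counterpart. The step that bears on it only in part, an at least 8.1-fold higher number from compound 1 to compound 2 (0.91 log units; beyond the scatter), ran toward a higher number when the cyano entered; compound 3 removes both that cyano and the ring that carries it, leaving a methyl on the sulfonamide nitrogen.

The expected change from compound 2 to compound 3 is an at least 2.0-fold lower number from compound 2 to compound 3 (0.30 log units; that floor lies within the scatter), with the direction uncertain as compound 2 is a limit. Compound 3 is estimated at 150000 nM, with a range from 40000 nM to 400000 nM.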

Compound 3, half-maximal cytotoxic concentration: 202000 nM
Beside the measured number, compound 3's estimate is 1.3-fold (0.13 log units) below it, within the range that was stated.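

Removing the phenyl from the saturated chain carbon bound to a sulfonamide nitrogen in a ring, which leaves a methyl at that place, gives a 5.4-fold higher number from compound 1 to compound 3 (0.73 log units; beyond the scatter) in this assay, so at this position a number beyond the scatter from the benzyl starting point is reached with no cyano present and with no aromatic ring on the chain at all. The full change from 3-cyanobenzyl to methyl gives an at least 1.5-fold lower number from compound 2 to compound 3 (0.17 log units; that floor lies within the scatter), which fixes only a floor for the size of that step and no firm ranking of the two groups. Compound 2 remains a limit of the assay, so how far it lies from compound 3 in this assay stays undetermined: the limit of > 305000 nM in this assay, at which 1 of the 3 values shown sits.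

The compounds shown leave open how the number changes along a longer chain, such as ethyl or propyl, at this place, and whether an amine or a carboxylic acid there would follow the same direction as methyl. They also leave open whether the benzyl group that all three compounds keep on the shared core responds to the same changes.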